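This account rests on a few compounds, and the source may have more. Where it says the series, first, only, none or still open, it means among the compounds named here.

Compound 1 `Fc1ccc(-c2ccc(-c3ccc(-c4nc5ccccc5[nH]4)cc3)cc2)cc1` gives 35600 nM
Compound 2 `FC(F)(F)Oc1ccc(-c2ccc(-c3ccc(-c4nc5ccccc5[nH]4)cc3)cc2)cc1` gives 100000 nM

In a functional assay on DWD cells (Homo sapiens) for inhibition, read by sulforhodamine B assay (on this read-out higher numbers stand for weaker inhibition of growth and lower numbers for stronger inhibition of growth), compound 2 at 100000 nM is the higher of the two numbers. Compound 3 `COc1ccc(-c2ccc(-c3ccc(-c4nc5ccccc5[nH]4)cc3)cc2)cc1` departs from compound 2 by one change (methyl in place of trifluoromethyl on an oxygen on an aromatic ring), methyl in place of trifluoromethyl on an oxygen on an aromatic ring. For the measured compounds named here, no measured step makes this exact change. The only one bearing on it is indirect (a 2.8-fold higher number from compound 1 to compound 2 (0.45 log units; beyond the scatter)), with trifluoromethoxy in place of fluoro. A step of similar modest size towards a lower number is therefore expected. Compound 3 is estimated at 40000 nM (expected range 15000 nM to 100000 nM). The expected step reads (a 2.5-fold lower number from compound 2 to compound 3 (0.40 log units; beyond the scatter)).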

Compound 3, concentration for 50% growth inhibition: 100000 nM
The estimate for compound 3 lay 2.5-fold (0.40 log units) below the measured number; the range from low to high includes it.
By their numbers in this assay, from the lowest: compound 1; then compounds 2 and 3 (each within the scatter of the next).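

In this assay, methyl in place of trifluoromethyl on the oxygen gives (no change at the digits printed from compound 2 to compound 3 (within the scatter)), so the two oxygen-linked groups cannot be told apart here. Fluoro, by contrast, stands apart from methoxy as well as from trifluoromethoxy, with (a 2.8-fold higher number from compound 1 to compound 3 (0.45 log units; beyond the scatter)), so compound 1 alone holds the lower number. Nothing measured here offers a reason for this.

On these data alone, it remains open whether an amine, a carboxylic acid or a longer alkoxy chain on this aromatic carbon would give a number lower than that of compound 1.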